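The source may hold more compounds than are shown below. What is called first, only, known or untested is meant among the compounds shown, and "the series" means these compounds.

In a functional assay on ECa-109 cells for inhibition, with ECa-109 cell line (Homo sapiens) as the target, read by sulforhodamine B assay (on this read-out higher numbers stand for weaker inhibition and lower numbers for stronger inhibition), three compounds with a shared core have been measured, and they differ only in the group on an amine nitrogen. Compound 1 `O=C1C(Nc2ccc(Br)cc2)=CC(=O)c2c1nc1n2[C@H]2OC[C@@H](O)[C@H]2OC1` gives 1980 nM. Compound 3 `COc1cccc(NC2=CC(=O)c3c(nc4n3[C@H]3OC[C@@H](O)[C@H]3OC4)C2=O)c1`, which carries 3-methoxyphenyl there, gives 3340 nM. The gap between these two numbers is small: the data show a 1.7-fold higher number from compound 1 to compound 3 (0.23 log units; within the scatter). Compound 2 `Cc1ccc(NC2=CC(=O)c3c(nc4n3[C@H]3OC[C@@H](O)[C@H]3OC4)C2=O)cc1` has no exact number, only a limit of the assay, > 4000 nM.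

Compound 4 `O=C1C(Nc2cccc(F)c2)=CC(=O)c2c1nc1n2[C@H]2OC[C@@H](O)[C@H]2OC1` keeps the core of compound 3 and has fluoro in place of methoxy on an aromatic carbon, meta to a large group: fluoro in place of methoxy on an aromatic carbon. Among the compounds with values here, no measured pair makes exactly this swap, so the nearest guide is the other changes to the same group. Within the data shown here, the one step with two exact numbers is a 1.7-fold higher number from compound 1 to compound 3 (0.23 log units; within the scatter). From the compounds shown here alone, the two steps that involve the limit give only floors, and their true sizes stay open: an at least 2.0-fold higher number from compound 1 to compound 2 (0.30 log units; that floor lies within the scatter) and an at least 1.1-fold lower number from compound 2 to compound 3 (0.07 log units; that floor lies within the scatter). On the basis of these steps, no change beyond the scatter is expected in this assay, and no direction is favoured. The estimated step is a 1.2-fold lower number from compound 3 to compound 4 (0.09 log units; within the scatter). For compound 4, the expected value is 2700 nM, with an estimated range from 1300 nM to 5500 nM.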

Compound 4, half-maximal inhibitory concentration: 2370 nM
Beside the measured number, compound 4's estimate is 1.1-fold (0.06 log units) above it; the range from low to high includes it.
By their numbers in this assay, from the lowest: compounds 1, 4 and 3 (each within the scatter of the next). At a limit, above all of these: compound 2.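

Within the data shown here, compound 4 gives the first direct reading of a swap on this aromatic carbon, meta to a large group, with the rest of the molecule unchanged. In this assay, replacing methoxy with fluoro gives a 1.4-fold lower number from compound 3 to compound 4 (0.15 log units; within the scatter), so this exchange, which removes a hydrogen-bond acceptor, produces no change that can be told apart from repeat-measurement noise. The comparison with the 4-bromophenyl compound gives a 1.2-fold higher number from compound 1 to compound 4 (0.08 log units; within the scatter), which places compounds 1, 3 and 4 within the scatter of one another, while the comparison with the 4-methylphenyl compound reads only as a floor, an at least 1.6-fold lower number from compound 2 to compound 4 (0.22 log units; that floor lies within the scatter), and its true size stays open because one of its values is a limit: the limit of > 4000 nM in this assay, at which 1 of the 4 values shown sits.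

The compounds shown carry only bromo, methyl, methoxy and fluoro on the phenyl ring, so it remains open whether this position can shift the number beyond the scatter at all. An amine, a carboxylic acid or a longer chain on the same aromatic carbon would test that, as would a comparison of fluoro at another place on the ring.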